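Mouse oral inhibition: from compound 2 to compound 3

The source may report more compounds than this note shows. Statements on the series, on what has been measured and on what is new or still open speak of the compounds shown alone.

Measured so far:
compound 1 `CN1C(=O)NC2(CC2(C)C)C1=O` gives 30%
compound 2 `CC1(C)CC12NC(=O)N(c1ccccc1)C2=O` gives 40%

Both numbers come from a functional assay on the whole organism for inhibition, with Mus musculus as the target, at a dose of 40 mg/kg by the oral route; a higher number here means a stronger effect of the compound at the dose given, a lower number a weaker effect. Compound 2 and compound 1 lie within the usual scatter of each other, so the two numbers give no order between them. Compound 3 `CC1(C)CC12NC(=O)N(c1ccc(F)cc1)C2=O` differs from compound 2 by fluoro in place of hydrogen on an aromatic carbon. Within the data shown here, no measured pair of compounds shows what such a change does here. The step from compound 2 to compound 3 is expected to be no change at the digits printed from compound 2 to compound 3 (within the scatter), nothing beyond the scatter in either direction. Compound 3 is therefore expected to give 40% in this assay, with a range from 25% to 55%.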

Compound 3, a percentage reported as inhibition, in the whole organism at one dose (the size of the read-out at that dose, not a potency): 50%
For compound 3 the middle estimate is 10 percentage points below the measured one; low and high end bracket the measured number.
By their numbers in this assay, from the lowest: compounds 1, 2 and 3 (each within the scatter of the next, the first and the last beyond it).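

In this assay, among these compounds, fluoro in place of hydrogen on an aromatic carbon, para to a large group, gives a number 10 percentage points higher from compound 2 to compound 3 (within the scatter) and so provides the first measured pair for this change. At this position, the fluoro group leaves the read-out at the single oral dose within the scatter of the hydrogen compound. Nothing available bears on a cause for this step.

Open, from the compounds shown here alone, is whether a larger group at the same position, such as an amine, a carboxylic acid or a longer chain, would move the read-out beyond the scatter. One pair also cannot show whether fluoro behaves the same way on other compounds.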